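Furan to pyridine on the hydrazone arm

The source may report more compounds than this note shows. Statements on the series, on what has been measured and on what is new or still open speak of the compounds shown alone.

Compound 1, `Cc1nc2cc(C(=O)NN)c([N+](=O)[O-])cc2[nH]1`: > 100000 nM
Compound 2, `CC(C)=NNC(=O)c1cc2nc(C)[nH]c2cc1[N+](=O)[O-]`: > 100000 nM
Compound 3, `Cc1nc2cc(C(=O)N/N=C\c3ccc(C)o3)c([N+](=O)[O-])cc2[nH]1`: > 100000 nM

Three compounds share one core and differ only in what sits on the amide-type nitrogen. In a functional assay on MCF7 cells (Homo sapiens) for cytotoxicity, read by resazurin assay, with a stated time of 72 h (on this read-out lower numbers stand for stronger inhibition and higher numbers for weaker inhibition), compound 1 gives > 100000 nM, which is a limit of the assay rather than a number. Compound 2 likewise gives > 100000 nM, again a limit. Compound 3 gives > 100000 nM, also a limit. Hence (the limit of > 100000 nM in this assay, at which 3 of the 3 values shown sit), and the steps between them cannot be read: a step that the two limits leave unreadable from compound 1 to compound 2, a step that the two limits leave unreadable from compound 1 to compound 3 and a step that the two limits leave unreadable from compound 2 to compound 3. Compound 3 therefore stands at the same limit as the other two, with no number of its own.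

The next compound, compound 4, `Cc1nc2cc(C(=O)N/N=C\c3ccccn3)c([N+](=O)[O-])cc2[nH]1`, differs from compound 3 by pyridin-2-yl in place of 5-methylfuran-2-yl on a carbon with a double bond to nitrogen. Within the data shown here, none of the measured steps gives a readable size, so there is no ground to expect a move beyond the scatter in this assay in either direction. Compound 4 is accordingly expected to sit at the same limit, with a number no higher from compound 3 to compound 4 (the limit leaves the size open) as the expected step. The estimate for compound 4 is 100000 nM, within a range from 30000 nM to 300000 nM.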

Compound 4, half-maximal inhibitory concentration: > 100000 nM
Compound 4: no number, only a limit (the forecaster's own chance of this, stated with the estimate: 80%); the middle value lies on the limit itself.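

In this assay compound 4 gives > 100000 nM, which is a limit and not a number. The steps to compound 4 from compound 1, compound 2 and compound 3 therefore cannot be read: the limit of > 100000 nM in this assay, at which 4 of the 4 values shown sit. The compounds shown leave open whether any group on the amide-type nitrogen moves the value at all.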